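The compounds below may be only part of what the source reports. "The series", "measured", "known", "first", "only" and "open" are said of these compounds alone.

Measured so far in an assay on isolated protein for binding affinity to 5-hydroxytryptamine receptor 6 (Homo sapiens), tested at 10 uM; a lower number here means less inhibition, a higher number more inhibition at the concentration tested (going by the name of the read-out):
compound 1, `CC(C)Cc1cc(CNS(=O)(=O)c2cccc3ccccc23)nn1-c1ccccc1`, gives 77.7%
compound 2, `CC(C)Cc1cc(CNS(=O)(=O)c2ccccc2)nn1-c1ccccc1`, gives 11.3%
compound 3, `CC(C)Cc1cc(CNS(=O)(=O)Cc2cccc3ccccc23)nn1-c1ccc(F)cc1`, gives 36.1%

Among these three, compound 2 stands lowest; compound 3 sits nearest to it and compound 1 furthest, both beyond the scatter. The piece follows the step from compound 2 to the unmeasured compound 4, `CC(C)Cc1cc(CNS(=O)(=O)c2c(Cl)cccc2Cl)nn1-c1ccccc1`. The change is 2,6-dichlorophenyl in place of phenyl on a sulfonyl sulfur.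

Among the compounds with values here, only one measured step touches the same place: a number 66.4 percentage points lower from compound 1 to compound 2 (beyond the scatter). It shows that what sits on the sulfonyl sulfur can move the read-out in this assay by a large amount, with the plain phenyl giving the lowest number. Compound 3 carries a different ring and a changed core, so it offers no single-change comparison with compound 2; its value only shows another compound above compound 2.

Since compound 4 keeps the phenyl but adds two chlorines, a rise is expected, smaller than the step to compound 1: a number 23.7 percentage points higher from compound 2 to compound 4 (beyond the scatter). For compound 4 the estimate is 35%, within 12% to 62%.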

Compound 4, a percentage reported as inhibition, at one concentration (the size of the read-out at that concentration, not a potency): 59.4%
The estimate for compound 4 lay 24.4 percentage points below the measured number; low and high end bracket the measured number.
By their numbers in this assay, from the lowest: compound 2; then compound 3; then compound 4; then compound 1.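

In this assay, a high number at this position on the sulfonyl sulfur does not require the fused naphthalen-1-yl group: adding chlorines to the phenyl recovers much of the loss, giving a number 48.1 percentage points higher from compound 2 to compound 4 (beyond the scatter). The 2,6-dichlorophenyl group still falls short of naphthalen-1-yl, with a number 18.3 percentage points lower from compound 1 to compound 4 (beyond the scatter), so the two groups are not equivalent in this read-out. No supporting measurement is available to explain why the chlorines raise the number.

Still open, as far as these compounds go, is whether a chlorophenyl group, or a dimethylphenyl or dimethoxyphenyl group in place of the 2,6-dichlorophenyl, would give a similar number. Also open, from the compounds shown here alone, is how a phenyl carrying an amine or a carboxylic acid would read at this position.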